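Swapping chloro for iodo on an aromatic ring

The source may report more compounds than this note shows. Statements on the series, on what has been measured and on what is new or still open speak of the compounds shown alone.

Of the compounds shown here, three have been tested so far in a functional assay on MDA-MB-231 cells (Homo sapiens) for cytotoxicity, read by MTT assay, with a stated time of 48 h; a higher number here means a weaker inhibitor, a lower number a stronger inhibitor. Compound 1 `Fc1ccc(C(CCCCOCc2ccc(Oc3ccc(Cl)cc3)cc2)c2ccc(F)cc2)cc1` gives only a limit of the assay, > 20000 nM, and not a number. Compound 2 `O=C(OCCCC(c1ccc(F)cc1)c1ccc(F)cc1)c1cc(Cl)c(OCc2ccccc2)c(Cl)c1` likewise gives only a limit, > 20000 nM. Among the measured compounds shown here, compound 3 `O=C(NCCCCC(c1ccc(F)cc1)c1ccc(F)cc1)Nc1ccc(Cl)cc1` is the only one with an actual number, 7680 nM, so it is the single firm reference point here.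

Compound 4 `O=C(NCCCCC(c1ccc(F)cc1)c1ccc(F)cc1)Nc1ccc(I)cc1` has not yet been measured. It carries iodo in place of the chloro of compound 3, on an aromatic carbon, para to a large group: iodo in place of chloro on an aromatic carbon. For the measured compounds named here, no measured pair shows a swap of this kind, so the expectation rests on compound 3 alone, at 7680 nM. The expected step, a 1.2-fold lower number from compound 3 to compound 4 (0.07 log units; within the scatter), is small and leans slightly towards stronger inhibition, with nothing beyond the usual scatter foreseen in this assay. For compound 4 the estimated value is 6500 nM, with an expected range from 2800 nM to 15000 nM.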

Compound 4, half-maximal inhibitory concentration: 11800 nM
Compound 4: the middle estimate sits 1.8-fold (0.26 log units) below what was measured, and the stated range covers the measured number.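

Among the compounds shown here, this is the first pair in the set that differs in one place, and it gives the first direct reading of this position in this assay. Iodo in place of chloro on this aromatic carbon gives a 1.5-fold higher number from compound 3 to compound 4 (0.19 log units; within the scatter), and a step of this size cannot be told apart from repeat measurements of a single compound. The position therefore accepts either atom without a readable change, and compound 3 and compound 4 both remain weak, in the upper part of the range this test can report: the limit of > 20000 nM in this assay, at which 2 of the 4 values shown sit.

The compounds shown carry only chloro and iodo at this place, and whether any group there can move the number beyond the scatter stays open. A carboxylic acid, an amine or a methoxy group on the same aromatic carbon would put that to the test.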